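The source may report more compounds than this note shows. Statements on the series, on what has been measured and on what is new or still open speak of the compounds shown alone.

Compound 1 `CCCCCCc1ccc(-c2c(C)[nH]c(=O)n2C)cc1` and compound 2 `CCCCCCCc1ccc(-c2c(C)[nH]c(=O)n2C)cc1` share a core and differ only in a chain. In a functional assay on brain (Rattus norvegicus, strain Wistar) for inhibition (on this read-out lower numbers stand for stronger inhibition and higher numbers for weaker inhibition), compound 1 gives 9000 nM, and compound 2 gives 8400 nM; the change methyl in place of hydrogen on a saturated chain carbon, six bonds along the chain from an aromatic carbon produced a 1.1-fold lower number from compound 1 to compound 2 (0.03 log units; within the scatter). Compound 3 `CCCCCCCCCCOc1ccc(-c2c(C)[nH]c(=O)n2C)cc1` carries the same core but a different chain, and in this assay compound 3 gives 6900 nM; the difference between compound 3 and compound 1 is not broken down here. Compound 4 `CCCCCCCCCCCOc1ccc(-c2c(C)[nH]c(=O)n2C)cc1` stands to compound 3 as compound 2 stands to compound 1: the change methyl in place of hydrogen on a saturated chain carbon, ten or more bonds along the chain from an oxygen on an aromatic ring is the same kind of change, though its place on the chain differs from that of the change from compound 1 to compound 2. Because the same kind of change gave a 1.1-fold lower number from compound 1 to compound 2 (0.03 log units; within the scatter), the step from compound 3 to compound 4 is expected to be small, about a 1.1-fold lower number from compound 3 to compound 4 (0.03 log units; within the scatter) in this assay. For compound 4 the expected value in this assay is 6500 nM, within 3000 nM to 13000 nM.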

Compound 4, half-maximal inhibitory concentration: 9700 nM
The estimate for compound 4 lay 1.5-fold (0.17 log units) below the measured number, within the range that was stated.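

In this assay, placing methyl in place of hydrogen on a saturated chain carbon, ten or more bonds along the chain from an oxygen on an aromatic ring, gives a 1.4-fold higher number from compound 3 to compound 4 (0.15 log units; within the scatter) in this second pair. Set beside the earlier pair, the same kind of change shows no difference between the two settings that can be told apart from ordinary assay noise: the same change on two cores in this assay, a 1.1-fold lower number (0.03 log units; within the scatter) from compound 1 to compound 2 and a 1.4-fold higher number (0.15 log units; within the scatter) from compound 3 to compound 4, 1.5-fold (0.18 log units) apart, within the scatter of two such steps. This suggests that, for these two pairs, adding one carbon to the chain leaves the inhibition number within the scatter, but it does not show that the two steps are truly equal, or that the change would behave alike on another core or at another place on the chain.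

From the compounds shown here alone, it remains open whether a group such as an amine or a carboxylic acid on the chain would give a step beyond the scatter. A much shorter chain, such as butyl, or a much longer one could also behave differently from the chains shown here.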